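A few compounds are considered here, and "the series" means these few. Any claim that something is new, unique, unknown or untested is made for them only; others in the source may bear on it.

Measured compounds in an assay on brain for displacement of a labelled ligand from D(3) dopamine receptor (Rattus norvegicus); on this read-out lower numbers stand for stronger inhibition and higher numbers for weaker inhibition:
- compound 1 `CCCN(CC[C@H]1CC[C@H](NC(=O)/C=C/c2ccc(Cl)cc2)CC1)[C@H]1CCc2nc(N)sc2C1` gives 2.5 nM
- compound 2 `CCCN(CC[C@H]1CC[C@H](NC(=O)/C=C/c2ccc(OC)cc2)CC1)[C@H]1CCc2nc(N)sc2C1` gives 6.7 nM
- compound 3 `CCCN(CC[C@H]1CC[C@H](NC(=O)c2cccc(-n3cncn3)c2)CC1)[C@H]1CCc2nc(N)sc2C1` gives 3 nM

Compound 1 has the lowest number of the three in this assay. Its gap to compound 3, a 1.2-fold higher number from compound 1 to compound 3 (0.08 log units; within the scatter), lies within the scatter, so no order between these two is claimed; its gap to compound 2, a 2.7-fold higher number from compound 1 to compound 2 (0.43 log units; beyond the scatter), is a modest step beyond the scatter, and the reverse exchange a 2.2-fold lower number from compound 2 to compound 3 (0.35 log units; beyond the scatter) is of similar size.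

Compound 4 `CCCN(CC[C@H]1CC[C@H](NS(=O)(=O)c2ccccc2Cl)CC1)[C@H]1CCc2nc(N)sc2C1` is not yet measured. It differs from compound 1 by (2-chlorophenyl)sulfonyl in place of (2-(4-chlorophenyl)ethenyl)carbonyl on an amine nitrogen. Going by the values given here, none of the measured steps exchanges the carbonyl itself; the steps from compound 1 to compound 2 and to compound 3 only vary what sits on the carbonyl carbon, and those changes moved the number by modest amounts or not beyond the scatter. The change to a sulfonyl on the amine nitrogen is therefore untested in this series, and a weakening step is expected in this assay, with wide uncertainty.

For compound 4 the expected value in this assay is 12 nM (range 3 nM to 50 nM), an estimated step of a 4.8-fold higher number from compound 1 to compound 4 (0.68 log units; beyond the scatter).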

Compound 4, inhibition constant: 0.68 nM
The estimate for compound 4 lay 18-fold (1.25 log units) above the measured number; the whole stated range lies above it.
By their numbers in this assay, from the lowest: compound 4; then compounds 1 and 3 (each within the scatter of the next); then compound 2.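

In this assay, going by these compounds alone, the exchange of (2-(4-chlorophenyl)ethenyl)carbonyl for (2-chlorophenyl)sulfonyl on the amine nitrogen gives a 3.7-fold lower number from compound 1 to compound 4 (0.57 log units; beyond the scatter) and is the first step that replaces the carbonyl itself. The earlier steps shown here varied only what sits on the carbonyl carbon, whereas compound 4 shows that a low number on this read-out does not depend on a carbonyl at this nitrogen. The linking group and the aryl part change together in this one step, and the data offer no explanation for its direction or size.

Still open, from the compounds shown here alone, is how much of the step belongs to the sulfonyl and how much to the 2-chlorophenyl, which a 2-chlorobenzoyl amide or a 4-chlorophenylsulfonyl group would help to separate. Also open, going by these compounds, is whether a methyl on the sulfonyl, or a urea in its place, would keep the number this low.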